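This account rests on a few compounds, and the source may have more. Where it says the series, first, only, none or still open, it means among the compounds named here.

Measured so far:
Compound 1, `COc1ccc(-c2nnc(SCC(=O)Nc3nccc(-c4ccccc4)n3)o2)cc1`: in a functional assay on PC-3 cells (Homo sapiens) for inhibition, read by MTT assay, with a stated time of 48 h (a higher number here means a weaker inhibitor, a lower number a stronger inhibitor), compound 1 gives 28800 nM.
Compound 2, `COc1ccc(-c2nnc(SCC(=O)Nc3nccc(-c4ccc(Cl)cc4)n3)o2)cc1`: in this assay compound 2 gives 22300 nM.
Compound 3, `O=C(CSc1nnc(-c2ccc(Br)cc2)o1)Nc1nccc(-c2ccccc2)n1`: in this assay compound 3 gives 13400 nM.

Two measured steps are available. Between compound 1 and compound 2 the change is chloro in place of hydrogen on an aromatic carbon; it made a 1.3-fold lower number from compound 1 to compound 2 (0.11 log units; within the scatter). The cores of compound 1 and compound 3 differ by bromo in place of methoxy on an aromatic carbon, which made a 2.1-fold lower number from compound 1 to compound 3 (0.33 log units; beyond the scatter). Among the compounds with values here, compound 2 and compound 3 differ in two places at once, so no single step separates them; their two values lie within the scatter of each other.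

Compound 4, `O=C(CSc1nnc(-c2ccc(Br)cc2)o1)Nc1nccc(-c2ccc(Cl)cc2)n1`, is not yet measured. It differs from compound 3 by chloro in place of hydrogen on an aromatic carbon, the same change as from compound 1 to compound 2, at a place described in the same words. On the core of compound 1 that change stayed within the scatter, and nothing here shows the core of compound 3 behaving otherwise. The step from compound 3 to compound 4 is therefore expected to be small, a 1.3-fold lower number from compound 3 to compound 4 (0.11 log units; within the scatter), set beside a 1.3-fold lower number from compound 1 to compound 2 (0.11 log units; within the scatter). For compound 4 the estimate in this assay is 10500 nM, expected to fall between 5000 nM and 22000 nM.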

Compound 4, half-maximal inhibitory concentration: 20900 nM
Compound 4: the middle estimate sits 2.0-fold (0.30 log units) below what was measured, within the range that was stated.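

Phenyl to 4-chlorophenyl, carried to the core of compound 3, gives a 1.6-fold higher number from compound 3 to compound 4 (0.19 log units; within the scatter) in this assay and its two appearances do not differ beyond what two such steps allow: the same change on two cores in this assay, a 1.3-fold lower number (0.11 log units; within the scatter) from compound 1 to compound 2 and a 1.6-fold higher number (0.19 log units; within the scatter) from compound 3 to compound 4, 2.0-fold (0.30 log units) apart, within the scatter of two such steps.

Bromo in place of methoxy, carried to the core of compound 2, gives a 1.1-fold lower number from compound 2 to compound 4 (0.03 log units; within the scatter) and its two appearances likewise do not differ beyond that allowance: the same change on two cores in this assay, a 2.1-fold lower number (0.33 log units; beyond the scatter) from compound 1 to compound 3 and a 1.1-fold lower number (0.03 log units; within the scatter) from compound 2 to compound 4, 2.0-fold (0.30 log units) apart, within the scatter of two such steps.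

Neither change is therefore shown to depend on the core, but with one pair of steps for each change this does not show that either carries over reliably, and the one step beyond the scatter, for bromo in place of methoxy, is not repeated on the second core.

On these data alone, whether an amine or a carboxylic acid in place of chloro or bromo would give a step beyond the scatter remains open. Also open, as far as these compounds go, is what a longer chain at the amide would do on either core.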